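Phenyl in place of 2,5-difluorophenyl in compound 1

A few compounds are considered here, and "the series" means these few. Any claim that something is new, unique, unknown or untested is made for them only; others in the source may bear on it.

Among the measured compounds shown here, in an ADME assay on BHK-21 cells (Mesocricetus auratus) for cytotoxicity, read by MTT assay, with a stated time of 96 h (on this read-out lower numbers stand for higher toxicity in this test and higher numbers for lower toxicity in this test), compound 1 `Fc1ccc(F)c(/N=N/c2ccc(NC[C@@H]3CCCN4CCCC[C@H]34)c3c2CCCC3)c1` gives 38000 nM as the only exact number in this small set. Compound 2 `COc1ccc(/N=N/N2CCCC2)cc1` is reported at >= 100000 nM in this assay and that result is a limit of the assay, not a number.

Compound 3 `c1ccc(/N=N/c2ccc(NC[C@@H]3CCCN4CCCC[C@H]34)c3c2CCCC3)cc1` differs from compound 1 in one place, with phenyl in place of 2,5-difluorophenyl on a double-bonded nitrogen and the core otherwise shared. For the measured compounds named here, no measured pair here shows what this change does, so the expectation in this assay rests on compound 1 at 38000 nM and no shift beyond the usual scatter is expected in either direction. The expected move a 1.1-fold higher number from compound 1 to compound 3 (0.02 log units; within the scatter) is an estimate that stays within that scatter. For compound 3 the estimated half-maximal cytotoxic concentration is 40000 nM with a range expected to run from 18000 nM to 90000 nM in this measurement.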

Compound 3, half-maximal cytotoxic concentration: > 100000 nM
Compound 3: only a limit was reported; the forecaster's own chance of this, stated with the estimate: 10%; middle value at least 2.5-fold (0.39 log units) away from the limit.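

Phenyl in place of 2,5-difluorophenyl on a double-bonded nitrogen gives an at least 2.6-fold higher number from compound 1 to compound 3 (0.42 log units; beyond the scatter) in this assay, the first sign in this set that this position bears on the read-out, with lower toxicity in this test for the compound without the fluorines. Compound 3 gives > 100000 nM, which is a limit of the assay and not a number. The true size of the step therefore stays unknown, and the printed step is only a lower bound on it: the limit of > 100000 nM in this assay, at which 1 of the 3 values shown sits.

The compounds shown leave open whether a single fluorine on the phenyl would already give this shift, and whether a chlorophenyl or pyridyl group in the same place would behave like phenyl or like 2,5-difluorophenyl. Among the compounds shown here, compound 2 differs from the others in more than one place, so no step to it can be read.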